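This account rests on a few compounds, and the source may have more. Where it says the series, first, only, none or still open, it means among the compounds named here.

Measured compounds in a functional assay on cells for antagonist activity at Free fatty acid receptor 1 (Homo sapiens), read by TR-FRET and inositol phosphate accumulation, with a stated time of 2 h; a lower number here means a stronger inhibitor, a higher number a weaker inhibitor:
Compound 1 `OC1CN(c2cc(COc3ccc(F)c(F)c3F)nc(-c3ccccn3)n2)C1` gives 3160 nM.
Compound 2 `Fc1ccc(OCc2cc(N3CC4(CCO4)C3)nc(-c3ccccn3)n2)c(F)c1F` gives 501 nM.
Compound 3 `CC1(CS(C)(=O)=O)CN(c2cc(COc3ccc(F)c(F)c3F)nc(-c3ccccn3)n2)C1` gives 6310 nM.

Compound 3 has the highest number of the three. Against compound 1 the step is a 2.0-fold higher number from compound 1 to compound 3 (0.30 log units; within the scatter), which stays within the scatter; against compound 2 it is a 13-fold higher number from compound 2 to compound 3 (1.10 log units; beyond the scatter), clearly beyond it. Compound 4 `Fc1ccc(OCc2cc(OCC(F)(F)F)nc(-c3ccccn3)n2)c(F)c1F` has not yet been measured. Its difference from compound 3 is 2,2,2-trifluoroethoxy in place of 3-methyl-3-((methylsulfonyl)methyl)azetidin-1-yl on an aromatic carbon. Among the measured compounds shown here, none of the measured steps matches this change: a 6.3-fold lower number from compound 1 to compound 2 (0.80 log units; beyond the scatter), a 2.0-fold higher number from compound 1 to compound 3 (0.30 log units; within the scatter) and a 13-fold higher number from compound 2 to compound 3 (1.10 log units; beyond the scatter) each keep a four-membered ring with one hetero atom at that position, whereas compound 4 carries no ring there. What they do show is that changes at this position move the number across the whole measured span, from compound 2 to compound 3. The expectation for compound 4 therefore rests on that span rather than on a matching step. The expected step in this assay is a 3.2-fold lower number from compound 3 to compound 4 (0.50 log units; beyond the scatter). Compound 4 is estimated at 2000 nM, with a range from 400 nM to 10000 nM.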

Compound 4, half-maximal inhibitory concentration: 7.94 nM
Estimate against measurement, compound 4: 250-fold (2.40 log units) above; measured number outside the range, below it.
By their numbers in this assay, from the lowest: compound 4; then compound 2; then compounds 1 and 3 (each within the scatter of the next).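

In this assay, putting 2,2,2-trifluoroethoxy on this aromatic carbon in place of the ring-bearing groups gives a large drop in each comparison (a 790-fold lower number from compound 3 to compound 4 (2.90 log units; beyond the scatter); a 400-fold lower number from compound 1 to compound 4 (2.60 log units; beyond the scatter); a 63-fold lower number from compound 2 to compound 4 (1.80 log units; beyond the scatter)). The earlier steps shown here all kept a four-membered ring at this position, so they showed only a narrower span, whereas this group without a ring takes the number far below all three earlier compounds. The information shown does not explain this drop.

The change replaces the ring, swaps the attached nitrogen for oxygen and brings in fluorine all at once, and the compounds shown do not separate these parts. A plain ethoxy group or a 2,2,2-trifluoroethylamino group on the same carbon would begin to pull them apart.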